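Glycine to alanine on the amide of compound 1

The source may report more compounds than this note shows. Statements on the series, on what has been measured and on what is new or still open speak of the compounds shown alone.

Measured so far:
compound 1, `Cc1ccc(N2CCN(C(=O)[C@@H]3CN(C4CCOCC4)C[C@H]3c3ccc(Cl)cc3)CC2)c([C@@H](NC(=O)CN)C(C)C)c1`: 2 nM
compound 2, `CC(C)[C@H](NC(=O)CCN(C)C)c1cccc(F)c1N1CCN(C(=O)[C@@H]2CN(C(C)C)C[C@H]2c2ccc(F)c(Cl)c2)CC1`: 260 nM

In an assay on HEK293 cells for displacement of a labelled ligand from Melanocortin receptor 4 (Homo sapiens) (a higher number here means a weaker inhibitor, a lower number a stronger inhibitor), compound 1 gives 2 nM, the lowest of the two numbers recorded. Compound 2 gives 260 nM in this assay, a far higher number that lies beyond the usual scatter; the two differ in several places at once, so nothing more can be read from that pair. Compound 3, `Cc1ccc(N2CCN(C(=O)[C@@H]3CN(C4CCOCC4)C[C@H]3c3ccc(Cl)cc3)CC2)c([C@@H](NC(=O)[C@H](C)N)C(C)C)c1`, differs from compound 1 in one place only: methyl in place of hydrogen on a saturated chain carbon bound to an amine nitrogen and a carbonyl carbon. Among the compounds with values here, no measured pair shows this change, so the step is expected to be small and within the scatter, read as a 1.5-fold higher number from compound 1 to compound 3 (0.18 log units; within the scatter). Compound 3 is therefore estimated at 3 nM in this assay, within 1 nM to 10 nM.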

Compound 3, inhibition constant: 1 nM
Beside the measured number, compound 3's estimate is 3.0-fold (0.48 log units) above it, within the range that was stated.
By their numbers in this assay, from the lowest: compounds 3 and 1 (each within the scatter of the next); then compound 2.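

In this assay, methyl in place of hydrogen on the saturated chain carbon bound to an amine nitrogen and a carbonyl carbon gives a step that stays within the scatter (a 2.0-fold lower number from compound 1 to compound 3 (0.30 log units; within the scatter)). Aminomethyl and 1-aminoethyl therefore cannot be told apart at this position, which the earlier compounds could not show. Nothing available bears on why the two read alike. From the compounds shown here alone, whether a longer chain such as 1-aminopropyl would also read alike at this carbon stays open, as does the effect of a hydroxyl group in place of the amine.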